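Lengthening the chain of compound 2

The source may report more compounds than this note shows. Statements on the series, on what has been measured and on what is new or still open speak of the compounds shown alone.

Measured in a functional assay on CNE-2 cells (Homo sapiens) for inhibition, read by MTT assay, with a stated time of 72 h; on this read-out higher numbers stand for weaker inhibition and lower numbers for stronger inhibition:
compound 1 `Nc1ncnc2c1c(-c1cnc3[nH]ccc3c1)nn2CCCCCC(=O)NO`: > 50000 nM
compound 2 `Nc1nc2cc(-c3nn(CCCCC(=O)NO)c4ncnc(N)c34)ccc2o1`: > 50000 nM
compound 3 `Nc1ncnc2c1c(-c1cnc3[nH]ccc3c1)nn2CCC(=O)NO`: > 150000 nM

All three entries are limits of the assay, not numbers. Compound 2 stands at > 50000 nM, which is a limit. The other two entries are limits as well, so no exact number is available for comparison.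

Compound 4 `Nc1nc2cc(-c3nn(CCCCCCC(=O)NO)c4ncnc(N)c34)ccc2o1` differs from compound 2 in one place: 2-(hydroxycarbamoyl)ethyl in place of hydroxycarbamoyl on a saturated chain carbon, four bonds along the chain from an aromatic nitrogen. Put simply, 2-(hydroxycarbamoyl)ethyl stands in place of hydroxycarbamoyl on a saturated chain carbon, four bonds along the chain from an aromatic nitrogen.

For the measured compounds named here, only one measured step bears on this kind of change: a step that the two limits leave unreadable from compound 1 to compound 3. It replaces 3-(hydroxycarbamoyl)propyl with hydroxycarbamoyl, but it gives neither a size nor a direction, and it comes from a different pair of compounds. The expectation in this assay is therefore cautious: a modest move toward stronger inhibition, with an even chance that only a limit is reported again. This caution rests on compound 2, whose > 50000 nM is a limit. The expected step is an at least 2.0-fold lower number from compound 2 to compound 4 (0.30 log units; that floor lies within the scatter). Compound 4 is estimated at 25000 nM, with an expected range of 2500 nM to 100000 nM.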

Compound 4, half-maximal inhibitory concentration: 4360 nM
The estimate for compound 4 lay 5.7-fold (0.76 log units) above the measured number; measured number inside the range.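

In this assay, for the compounds shown here, compound 4 gives the only exact number among the four compounds, 4360 nM, so this is the first change here whose direction can be read. Putting 2-(hydroxycarbamoyl)ethyl in place of hydroxycarbamoyl, on a saturated chain carbon, four bonds along the chain from an aromatic nitrogen, gives an at least 11-fold lower number from compound 2 to compound 4 (1.05 log units; beyond the scatter), a step well beyond the usual scatter. That size is a floor rather than a full measure, because compound 2 stands at a limit and not at a number: the limit of > 50000 nM in this assay, at which 2 of the 4 values shown sit.

The step from compound 1 to compound 3, which also changes the chain length but on a different core, still cannot be read, so this one result does not establish a trend across both cores. As far as these compounds go, it remains open whether a longer chain than that of compound 4 would lower the number further or raise it again, and whether a carboxylic acid in place of the hydroxycarbamoyl at the chain end would keep any of this inhibition.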